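A few compounds are considered here, and "the series" means these few. Any claim that something is new, unique, unknown or untested is made for them only; others in the source may bear on it.

Measured in a physicochemical assay for solubility, in phosphate buffer, measured as kinetic solubility, at pH 7.4 (on this read-out lower numbers stand for lower solubility and higher numbers for higher solubility), so far:
- Compound 1 `Cc1ccccc1-c1nc(CN2CCC(C(=O)NCCCN3CCC(C)(C)CC3)CC2)c(C)o1` gives > 69 ug/mL as a limit
- Compound 2 `Cc1ccccc1-c1nc(CN2CCC(C(=O)NCCCN3CCCCC3)CC2)c(C)o1` gives > 65 ug/mL as a limit
- Compound 3 `Cc1ccccc1-c1nc(CN2CCC(C(=O)NCCN3C[C@H](C)C[C@H](C)C3)CC2)c(C)o1` gives > 67 ug/mL as a limit

Compound 3 stands at > 67 ug/mL and this is a limit, not a number. The other two compounds also sit at limits, so the three cannot be ranked. The next structure is compound 4 `Cc1ccccc1-c1nc(CN2CCC(C(=O)N3CCN(CCN(C)C)CC3)CC2)c(C)o1` and the change is a group of 11 heavy atoms (8 carbon, 3 nitrogen; one six-membered non-aromatic ring with 2 hetero atoms) in place of a group of 11 heavy atoms (9 carbon, 2 nitrogen; one six-membered non-aromatic ring with 1 hetero atom), on a carbonyl carbon on a carbonyl carbon. Three measured steps are available: a step that the two limits leave unreadable from compound 1 to compound 2 and a step that the two limits leave unreadable from compound 1 to compound 3 and a step that the two limits leave unreadable from compound 2 to compound 3 all on a saturated chain carbon, not on the carbonyl carbon. None of them has a readable size, so they give no direction or magnitude to carry over. In this assay no step beyond the usual scatter is therefore expected. The estimated change is a number no higher from compound 3 to compound 4 (the limit leaves the size open) in size. For compound 4 the estimate is 67 ug/mL with an expected range from 52 ug/mL to 72 ug/mL. The result may well be a limit again.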

Compound 4, solubility: > 67 ug/mL
Compound 4: no number, only a limit; the forecaster's own chance of this, stated with the estimate: 85%; the middle value sits exactly at the limit.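

In this assay compound 4 gives > 67 ug/mL, which is a limit and not a number, so the steps to compound 4 from compound 2 and from compound 3 cannot be read. The compounds shown leave open how large any difference in solubility between them is, or whether one exists.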